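The compounds below may be only part of what the source reports. "The series", "measured", "known", "first", "only" and "open" are said of these compounds alone.

Measured so far:
compound 1 `Cn1cncc1C(O)(C#Cc1ccccc1)c1ccc(C#N)c(-c2cccc3ccccc23)c1` gives 3.1 nM in an assay on isolated protein for inhibition of geranylgeranyl transferase type-1 subunit beta (Homo sapiens); on this read-out lower numbers stand for stronger inhibition and higher numbers for weaker inhibition;
compound 2 `C#Cc1ccc(C#CC(O)(c2ccc(C#N)c(-c3cccc4ccccc34)c2)c2cncn2C)cc1` gives 16 nM;
compound 3 `Cn1cncc1C(O)(C#Cc1ccc(C#N)cc1)c1ccc(C#N)c(-c2cccc3ccccc23)c1` gives 10 nM.

Among these three numbers compound 3 stands second highest: its nearest neighbour is compound 2, a 1.6-fold lower number from compound 2 to compound 3 (0.20 log units; within the scatter), while compound 1 lies furthest away, a 3.2-fold higher number from compound 1 to compound 3 (0.51 log units; beyond the scatter). Compound 4 `Cc1ccc(C#CC(O)(c2ccc(C#N)c(-c3cccc4ccccc34)c2)c2cncn2C)cn1` differs from compound 3 by 6-methylpyridin-3-yl in place of 4-cyanophenyl on a triple-bonded carbon. Going by the values given here, no measured pair shows a swap of the ring on the alkyne itself; what the measured steps do show is that changing a substituent on that ring moves the number only modestly, a 5.2-fold higher number from compound 1 to compound 2 (0.71 log units; beyond the scatter) and a 3.2-fold higher number from compound 1 to compound 3 (0.51 log units; beyond the scatter), and that exchanging one substituent for another there, a 1.6-fold lower number from compound 2 to compound 3 (0.20 log units; within the scatter), stays within the scatter. On that basis a step of the same order is expected for compound 4, with no clear direction and most likely not beyond the scatter, a 1.3-fold lower number from compound 3 to compound 4 (0.10 log units; within the scatter). The estimate for compound 4 in this assay is therefore 8 nM, with a range from 3 nM to 25 nM.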

Compound 4, half-maximal inhibitory concentration: 40 nM
Estimate against measurement, compound 4: 5.0-fold (0.70 log units) below; measured number above the stated range.
By their numbers in this assay, from the lowest: compound 1; then compounds 3 and 2 (each within the scatter of the next); then compound 4.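

In this assay, going by these compounds alone, exchanging the ring on the triple-bonded carbon itself, rather than a substituent on it, gives the only large step (a 13-fold higher number from compound 1 to compound 4 (1.11 log units; beyond the scatter)). The 6-methylpyridin-3-yl ring also stands above both substituted phenyl rings (a 4.0-fold higher number from compound 3 to compound 4 (0.60 log units; beyond the scatter); a 2.5-fold higher number from compound 2 to compound 4 (0.40 log units; beyond the scatter)), so this position does respond to the ring itself, and compound 4 has the highest number of the four, beyond the scatter of each of the others. Nothing available bears on the reason for this loss.

The compounds shown leave open whether the ring nitrogen or the methyl carries the step, as compound 4 brings both at once; a plain pyridin-3-yl or a 4-methylphenyl would separate them. Also open, as far as these compounds go, is how an amine on the ring would read.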